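Trimming the Isopentyl Chain of Compound 3

The source may hold more compounds than are shown below. What is called first, only, known or untested is meant among the compounds shown, and "the series" means these compounds.

In an ADME assay on Vero cells (Chlorocebus sabaeus) for cytotoxicity, read by resazurin assay, with a stated time of 24 h (on this read-out higher numbers stand for lower toxicity in this test and lower numbers for higher toxicity in this test), compound 1 (`CCCCCO[C@@H]1C=CC(=O)[C@@H](COC(=O)C(C)(C)C)O1`) gives 7380 nM, compound 2 (`CCCCO[C@@H]1C=CC(=O)[C@@H](COC(=O)C(C)(C)C)O1`) gives 42500 nM and compound 3 (`CC(C)CCO[C@@H]1C=CC(=O)[C@@H](COC(=O)C(C)(C)C)O1`) gives 36000 nM. Two measured steps fix the place of compound 3: a 1.2-fold lower number from compound 2 to compound 3 (0.07 log units; within the scatter), and a 4.9-fold higher number from compound 1 to compound 3 (0.69 log units; beyond the scatter). Compound 4 (`CC(C)CO[C@@H]1C=CC(=O)[C@@H](COC(=O)C(C)(C)C)O1`) differs from it by isopropyl in place of isobutyl on a saturated chain carbon bound to an oxygen on a saturated carbon. The closest measured trimming, a 5.8-fold higher number from compound 1 to compound 2 (0.76 log units; beyond the scatter), was modest, but it started from compound 1, which has the lowest number. The step under review starts from the level of compound 2 instead, so no change beyond the scatter is expected. The expected step is a 1.3-fold higher number from compound 3 to compound 4 (0.10 log units; within the scatter). For compound 4 the estimate is 45000 nM, with an expected range of 20000 nM to 100000 nM.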

Compound 4, half-maximal cytotoxic concentration: 28200 nM
The estimate for compound 4 lay 1.6-fold (0.20 log units) above the measured number; low and high end bracket the measured number.
By their numbers in this assay, from the lowest: compound 1; then compounds 4, 3 and 2 (each within the scatter of the next).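

At this place, on a saturated chain carbon bound to an oxygen on a saturated carbon, isopropyl in place of isobutyl gives a 1.3-fold lower number from compound 3 to compound 4 (0.11 log units; within the scatter), and isopropyl in place of propyl gives a 1.5-fold lower number from compound 2 to compound 4 (0.18 log units; within the scatter). Going by these compounds alone, the one new step beyond the scatter is the one that removes the unbranched chain of the lowest-reading compound: a 3.8-fold higher number from compound 1 to compound 4 (0.58 log units; beyond the scatter). The same change therefore does not carry over from one chain to another: the same change on two cores in this assay, a 4.9-fold higher number (0.69 log units; beyond the scatter) from compound 1 to compound 3 and a 1.5-fold lower number (0.18 log units; within the scatter) from compound 2 to compound 4, 7.4-fold (0.87 log units) apart, beyond the scatter of two such steps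

From the compounds shown here alone, how an ethyl chain, a cyclohexyl group or a chain ending in an amine would read at this place remains open.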